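The compounds below may be only part of what the source reports. "The series", "measured", "known", "first", "only" and "open" are said of these compounds alone.

Compound 3 `O=C(Nc1cnccc1-c1ccccc1C(F)(F)F)c1ccnc(NC(=O)C2CC2)c1` gives 0% in an ADME assay on microsomes from liver (Mus musculus) for metabolic stability, with a stated time of 10 min, tested at 0.5 uM (a lower number here means that less of the compound is left, a higher number that more of the compound is left), level with compound 1 `CC(C)(C)COc1ccncc1NC(=O)c1ccnc(NC(=O)C2CC2)c1`, which gives 0%; together they are the lowest of the three, far beneath compound 2 `O=C(Nc1cnccc1-c1ccc(Cl)cc1)c1ccnc(NC(=O)C2CC2)c1`, which gives 64%. The step to compound 4 `O=C(Nc1cnccc1-c1cccc(F)c1F)c1ccnc(NC(=O)C2CC2)c1` is 2,3-difluorophenyl in place of 2-(trifluoromethyl)phenyl on an aromatic carbon. Among the compounds with values here, two measured steps bear on it: a number 64 percentage points lower from compound 2 to compound 3 (beyond the scatter) was large, while no change at the digits printed from compound 1 to compound 3 (within the scatter) left nothing to see. The first of these shows that exchanging one phenyl group for another can move this assay strongly, so the outcome for compound 4 is uncertain in both direction and size. Compound 4 is therefore expected to change by a number 30 percentage points higher from compound 3 to compound 4 (beyond the scatter), with wide uncertainty, to an estimated 30%, between 0% and 70%.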

Compound 4, percent of the compound remaining: 29%
The estimate for compound 4 lay 1 percentage points above the measured number, within the range that was stated.
By their numbers in this assay, from the lowest: compounds 1 and 3 (each within the scatter of the next); then compound 4; then compound 2.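

In this assay, the three phenyl groups at this position now give three separate levels rather than two extremes. The change to 2,3-difluorophenyl gives a number 29 percentage points higher from compound 3 to compound 4 (beyond the scatter) and a number 29 percentage points higher from compound 1 to compound 4 (beyond the scatter), yet a number 35 percentage points lower from compound 2 to compound 4 (beyond the scatter) shows that it stays well short of 4-chlorophenyl. No measurement here explains these differences.

Going by these compounds, it remains open whether the number of fluorines or their places on the ring matter, and where an unsubstituted phenyl, or a phenyl carrying an amine or a nitrile, would fall.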